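Swapping an ethyl for benzylamino on a weak pyridine amide

The source may report more compounds than this note shows. Statements on the series, on what has been measured and on what is new or still open speak of the compounds shown alone.

The shared core, seen in compound 2 `CCCOc1ccc(C(=O)Nc2cccc(CC)n2)cc1`, carries an amide to a propoxy-bearing ring. In an in vitro assay on HEK-tsA201 cells for antagonist activity at Neuronal acetylcholine receptor; alpha4/beta2 (Homo sapiens), read by fluorescence and calcium flux (on this read-out lower numbers stand for stronger inhibition and higher numbers for weaker inhibition), compound 2 gives 37600 nM, and compound 1 `CCCOc1ccc(C(=O)Nc2cnccn2)cc1` gives in this assay 23200 nM; the gap between these two numbers lies within the usual scatter, so neither can be called apart from the other. Both numbers mean only weak inhibition.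

Compound 3 `CCCOc1ccc(C(=O)Nc2cccc(NCc3ccccc3)n2)cc1` changes one spot on the core: benzylamino in place of ethyl on an aromatic carbon. Among the measured compounds shown here, no pair of measured compounds shows this kind of exchange, so there is no measured step to lean on. A change of this size may shift the number in either direction, yet with only weak inhibition seen so far no large gain is expected. The estimated step of a 1.9-fold lower number from compound 2 to compound 3 (0.27 log units; within the scatter) is therefore taken as small. Compound 3 is expected to give about 20000 nM, within a range from 5000 nM to 80000 nM.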

Compound 3, half-maximal inhibitory concentration: > 100000 nM
Compound 3 ended at the assay's limit; the forecaster's own chance of this, stated with the estimate: 15%; at least 5.0-fold (0.69 log units) between middle value and limit.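

The position next to the ring nitrogen is not indifferent to what it carries: benzylamino in place of ethyl gives an at least 2.6-fold higher number from compound 2 to compound 3 (0.42 log units; beyond the scatter), so in this assay inhibition that was already weak becomes weaker still. A larger group with an aromatic ring of its own and a hydrogen-bond donor brings no gain here, although this single exchange cannot tell which part of it matters. The step is only a minimum, since compound 3 stands at a limit of the assay and not at a number: the limit of > 100000 nM in this assay, at which 1 of the 3 values shown sits.

From the compounds shown here alone, it remains open whether the loss follows the nitrogen or the added ring, and a plain amino group or a benzyl group at this position would help separate the two. Going by these compounds, whether any group here can strengthen inhibition also remains unknown.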